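This account rests on a few compounds, and the source may have more. Where it says the series, first, only, none or still open, it means among the compounds named here.

Of the compounds shown here, three sharing one core have been tested in a functional assay on K562 cells (Homo sapiens) for antiproliferative activity, with a stated time of 72 h; a lower number here means a stronger inhibitor, a higher number a weaker inhibitor. Compound 1 `CCCCC#Cc1cc([C@@H]2O[C@H](CO)[C@@H](O)[C@H]2O)n2ncnc(N)c12`, carrying hex-1-yn-1-yl, gives 2400 nM, and compound 3 `Nc1ncnn2c([C@@H]3O[C@H](CO)[C@@H](O)[C@H]3O)cc(/C=C/c3ccccc3)c12`, carrying 2-phenylethenyl, gives 3100 nM, so these two values lie within the scatter of each other. Compound 2 `Nc1ncnn2c([C@@H]3O[C@H](CO)[C@@H](O)[C@H]3O)cc(C#Cc3ccc(F)cc3)c12`, carrying 2-(4-fluorophenyl)ethynyl, reports only a limit, > 100000 nM.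

Compound 4 `Nc1ncnn2c([C@@H]3O[C@H](CO)[C@@H](O)[C@H]3O)cc(-c3ccsc3)c12` is the next case, with thiophen-3-yl in place of 2-phenylethenyl on an aromatic carbon. Among the measured compounds shown here, no measured step brings in this group, so the evidence is indirect. Exchanges at this same place gave a 1.3-fold higher number from compound 1 to compound 3 (0.11 log units; within the scatter), but also an at least 41-fold higher number from compound 1 to compound 2 (1.61 log units; beyond the scatter) and an at least 32-fold lower number from compound 2 to compound 3 (1.50 log units; beyond the scatter). For the measured compounds named here, both large steps involve the one limit value, while the only step between two actual numbers, a 1.3-fold higher number from compound 1 to compound 3 (0.11 log units; within the scatter), stays small. A change beyond the scatter is therefore not expected, although the uncertainty is wide. The expected step is a 1.6-fold lower number from compound 3 to compound 4 (0.19 log units; within the scatter). In this assay the estimate for compound 4 is 2000 nM, with an expected range from 200 nM to 30000 nM.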

Compound 4, half-maximal inhibitory concentration: 66400 nM
The estimate for compound 4 lay 33-fold (1.52 log units) below the measured number; the measured number lies above the stated range.
By their numbers in this assay, from the lowest: compounds 1 and 3 (each within the scatter of the next); then compound 4. At a limit, above all of these: compound 2.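

In this assay, among the compounds shown here, the exchange of 2-phenylethenyl for thiophen-3-yl shows that this aromatic carbon can produce a large step between two actual numbers, which the earlier compounds showed only against a limit: a 21-fold higher number from compound 3 to compound 4 (1.33 log units; beyond the scatter), and likewise a 28-fold higher number from compound 1 to compound 4 (1.44 log units; beyond the scatter). Hex-1-yn-1-yl and 2-phenylethenyl therefore remain the two groups with the lowest numbers, while thiophen-3-yl stands with 2-(4-fluorophenyl)ethynyl at the weak end of the series. Compound 2 is reported only as a limit, so an at least 1.5-fold lower number from compound 2 to compound 4 (0.17 log units; that floor lies within the scatter) is only a floor: the limit of > 100000 nM in this assay, at which 1 of the 4 values shown sits.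

The compounds shown leave open whether a phenyl ring attached directly at this carbon would behave like the thiophen-3-yl of compound 4. They also leave open how an ethynyl-linked thiophene or an amine at this carbon would compare.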